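Pyridin-2-yl in Place of 4-Chlorophenyl: An Expected Loss

The compounds below may be only part of what the source reports. "The series", "measured", "known", "first", "only" and "open" are said of these compounds alone.

Of the compounds shown here, three sharing one core have been tested in a functional assay on HepG2 cells (Homo sapiens) for inhibition, read by MTT assay, with a stated time of 72 h; a higher number here means a weaker inhibitor, a lower number a stronger inhibitor. Among the compounds with values here, compound 2 `CC(C)(C)n1cc2c(n1)C(=O)CC1(CCN(C(=O)c3cc(-c4ccc(Cl)cc4)nc4ccccc34)CC1)O2` is the only one to return a number, 630 nM. Compound 1 `Cc1ccccc1-c1cc(C(=O)N2CCC3(CC2)CC(=O)c2nn(C(C)(C)C)cc2O3)c2ccccc2n1` reaches only a limit of the assay, > 10000 nM. Compound 3 `CC(C)(C)n1cc2c(n1)C(=O)CC1(CCN(C(=O)c3cc(-c4ccccc4Cl)nc4ccccc34)CC1)O2` likewise stops at a limit, > 10000 nM. Two of the three values thus sit at the limit of > 10000 nM in this assay, at which 2 of the 3 values shown sit, so compound 2 stands alone as the single measured point, and both readable steps run steeply away from it: an at least 15-fold lower number from compound 1 to compound 2 (1.20 log units; beyond the scatter) and an at least 15-fold higher number from compound 2 to compound 3 (1.20 log units; beyond the scatter). The aryl group on the core evidently decides whether a number appears at all.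

Compound 4 `CC(C)(C)n1cc2c(n1)C(=O)CC1(CCN(C(=O)c3cc(-c4ccccn4)nc4ccccc34)CC1)O2` differs from compound 2 by pyridin-2-yl in place of 4-chlorophenyl on an aromatic carbon. Within the data shown here, no measured pair contains a pyridin-2-yl, so the step can only be judged from how sharply this assay responded to the two other changes of aryl group, each of which pushed the value to the limit. A higher number is therefore expected, probably a large one. Compound 4 is estimated at 3500 nM, within a range of 900 nM to 12000 nM. That expectation corresponds to an estimated step of a 5.6-fold higher number from compound 2 to compound 4 (0.74 log units; beyond the scatter), with a real chance that only a limit is reported.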

Compound 4, half-maximal inhibitory concentration: 1500 nM
Compound 4: the middle estimate sits 2.3-fold (0.37 log units) above what was measured, within the range that was stated.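

Within the data shown here, compound 4 shows that 4-chlorophenyl is not the only group at this position, on an aromatic carbon next to the ring nitrogen, that gives a number in this assay: the change to pyridin-2-yl, which removes the chlorine and brings in a ring nitrogen, costs a 2.4-fold higher number from compound 2 to compound 4 (0.38 log units; beyond the scatter). The same group also stands clearly apart from the two groups that carry their substituent on the 2-position of a phenyl ring, with an at least 6.6-fold lower number from compound 3 to compound 4 (0.82 log units; beyond the scatter) and an at least 6.6-fold lower number from compound 1 to compound 4 (0.82 log units; beyond the scatter). Compound 1 and compound 3 each stop at a limit, so these last two steps are bounds and not exact sizes, because neither starts from a true number: the limit of > 10000 nM in this assay, at which 2 of the 4 values shown sit.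

The step from compound 2 to compound 4 changes the chlorine and the ring atom together, so plain phenyl would be needed to separate the two, and the compounds shown cannot say which of them accounts for the modest difference. As far as these compounds go, how pyridin-3-yl, pyridin-4-yl or 4-methoxyphenyl would behave at this position also remains open.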